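The source may report more compounds than this note shows. Statements on the series, on what has been measured and on what is new or still open speak of the compounds shown alone.

Measured so far in an ADME assay on MT2 cells (Homo sapiens) for cytotoxicity (on this read-out lower numbers stand for higher toxicity in this test and higher numbers for lower toxicity in this test), for this series:
compound 1 `CNCc1cc(N)c(Nc2ccc(C#N)cc2)cc1Oc1c(C)cc(C#N)cc1C` gives 12700 nM
compound 2 `COCc1cc(N)c(Nc2ccc(C#N)cc2)cc1Oc1c(C)cc(/C=C/C#N)cc1C` gives 50300 nM
compound 3 `CC(=O)OCc1cc(N)c(Nc2ccc(C#N)cc2)cc1Oc1c(C)cc(/C=C/C#N)cc1C` gives 96300 nM

Compound 3 stands within the scatter of compound 2, and the gap to compound 1 lies beyond the scatter, with compound 1 the lower of the two. The next compound is compound 4 `CC(=O)OCc1cc(N)c(Nc2ccc(C#N)cc2)cc1Oc1c(C)cc(CCC#N)cc1C`, which carries 2-cyanoethyl in place of 2-cyanoethenyl on an aromatic carbon. Among the measured compounds shown here, no measured step changes this group. For the measured compounds named here, the only single-place step, a 1.9-fold higher number from compound 2 to compound 3 (0.28 log units; within the scatter), concerns a different part of the molecule and stays within the scatter. It therefore offers no measure of this change, and no shift beyond the scatter is expected in this assay on this evidence. The expected change is a 1.2-fold lower number from compound 3 to compound 4 (0.08 log units; within the scatter), which is an estimate and remains within the scatter. For compound 4 the estimated value is 80000 nM, with an expected range from 30000 nM to 200000 nM.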

Compound 4, half-maximal cytotoxic concentration in the MT2 assay: 44800 nM
Estimate against measurement, compound 4: 1.8-fold (0.25 log units) above, within the range that was stated.
By their numbers in the MT2 assay, from the lowest: compound 1; then compounds 4, 2 and 3 (each within the scatter of the next, the first and the last beyond it).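

Among the compounds shown here, in the MT2 assay, 2-cyanoethyl in place of 2-cyanoethenyl gives a 2.1-fold lower number from compound 3 to compound 4 (0.33 log units; beyond the scatter) with compound 3 at 96300 nM and compound 4 at 44800 nM and is the first measured step at this position, which shows that the read-out responds to this change, if only modestly. In a physicochemical assay for solubility, read by HPLC, at pH 2 (on this read-out lower numbers stand for lower solubility and higher numbers for higher solubility), the same change gives a 1.4-fold higher number from compound 3 to compound 4 (0.15 log units; within the scatter) with compound 3 at 1.87 ug/mL and compound 4 at 2.63 ug/mL and so shows no clear shift in solubility between these two compounds. Nothing available accounts for the step in either read-out.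

As far as these compounds go, whether a longer chain or a carboxylic acid in place of the nitrile-bearing chain would move either read-out remains open. From the compounds shown here alone, it is also open whether this change gives a step of similar size when the rest of the molecule is that of compound 2.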